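The source may hold more compounds than are shown below. What is called first, only, known or untested is meant among the compounds shown, and "the series" means these compounds.

Measured so far:
compound 1 `COc1cc(=O)oc2cc(OCc3cccc(F)c3)ccc12` with 49%;
compound 2 `O=C(COc1cc(=O)oc2cc(OCc3cccc(Cl)c3)ccc12)N1CCCCC1` with 9%;
compound 3 `O=c1cc(CO)c2ccc(OCc3cccc(Br)c3)cc2o1` with 49%.

In an assay on isolated protein (strain Sprague-Dawley) for inhibition of Amine oxidase [flavin-containing] A (Rattus norvegicus), read by spectrophotometry, with a stated time of 5 min, tested at 10 uM (a lower number here means less inhibition, a higher number more inhibition at the concentration tested (going by the name of the read-out)), compound 2 stands lowest of the three numbers. Its nearest neighbour, compound 1, gives 49%, which lies beyond the scatter above it, and compound 3 gives 49%, also beyond the scatter above it. Compounds 1 and 3 lie within the scatter of each other, so no order between them is claimed.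

The next compound, compound 4 `O=C(O)c1cc(=O)oc2cc(OCc3cccc(Cl)c3)ccc12`, is not yet measured in this assay. It differs from compound 2 in one place: carboxy in place of ((piperidin-1-yl)carbonyl)methoxy on an aromatic carbon. Among the compounds with values here, no step between measured compounds shares this change, so the direction of the step has to be judged from the three numbers alone. Compounds 1 and 3, carrying a group of few heavy atoms at the position in question, stand well above compound 2, which carries the larger ((piperidin-1-yl)carbonyl)methoxy. An upward step beyond the scatter is therefore expected for compound 4, with the step from compound 2 to compound 4 estimated as a number 26 percentage points higher from compound 2 to compound 4 (beyond the scatter). For compound 4 the estimate in this assay is 35%, between 10% and 60%.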

Compound 4, a percentage reported as inhibition, at one concentration (the size of the read-out at that concentration, not a potency): 0%
Beside the measured number, compound 4's estimate is 35 percentage points above it; the measured number lies below the stated range.
By their numbers in this assay, from the lowest: compounds 4 and 2 (each within the scatter of the next); then compounds 1 and 3 (each within the scatter of the next).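

In this assay, carboxy in place of ((piperidin-1-yl)carbonyl)methoxy on this aromatic carbon, opposite the ring oxygen, gives a number 9 percentage points lower from compound 2 to compound 4 (within the scatter). Removing the six-membered non-aromatic ring and going from 10 heavy atoms to 3 at this position therefore leaves the read-out unresolved, so a group of few heavy atoms is not enough on its own to separate compound 4 from compound 2. Nothing measured here explains this result, and no separate measurement of any property of these groups is available.

As far as these compounds go, compounds 1 and 3 differ from compound 4 in more than one place, so the separate contributions of the group at this position and the halogen on the benzyl ether remain open. From the compounds shown here alone, it is also open how a methyl ester or an aminomethyl group at this position would read out on the core of compound 4.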